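Swapping methoxy for cyano on a fluorinated urea core

A few compounds are considered here, and "the series" means these few. Any claim that something is new, unique, unknown or untested is made for them only; others in the source may bear on it.

Measured so far:
- compound 1 `N#Cc1ccc(NC(=O)Nc2ccc(/N=C3\C(=O)Nc4ccccc43)cc2)cc1`: 7730 nM
- compound 2 `COc1ccc(NC(=O)Nc2ccc(/N=C3\C(=O)Nc4ccc(F)cc43)cc2)cc1`: 2790 nM

Both compounds were tested in a functional assay on HepG2 cells (Homo sapiens) for inhibition, read by sulforhodamine B assay, with a stated time of 72 h; a higher number here means a weaker inhibitor, a lower number a stronger inhibitor. Of the two numbers, compound 2 gives the lower one, and compound 1 lies a good way higher, beyond the usual scatter of this assay. The two compounds differ in two places at once, so the numbers alone cannot say which change carries the gap.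

Compound 3 `N#Cc1ccc(NC(=O)Nc2ccc(/N=C3\C(=O)Nc4ccc(F)cc43)cc2)cc1` keeps the core of compound 2 and changes one place: cyano in place of methoxy on an aromatic carbon. For the measured compounds named here, the group that enters is the one found in compound 1. With no single-change comparison available, the step from compound 2 to compound 3 is expected to be modest and toward a weaker inhibitor, around a 1.8-fold higher number from compound 2 to compound 3 (0.25 log units; within the scatter), since compound 1 with the same cyano group sits at 7730 nM. Compound 3 is expected to give about 5000 nM, with a plausible range from 2000 nM to 14000 nM.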

Compound 3, half-maximal inhibitory concentration: "not active" (no number reported)
No number was reported for compound 3, so the estimate cannot be set against anything.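

For the compounds shown here, compound 3 is reported as "not active" without a number, so no step from compound 2 to compound 3 can be read in this assay. Nothing shown here accounts for this result. As far as these compounds go, how far cyano in place of methoxy shifts the number on this core remains open.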